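The source may hold more compounds than are shown below. What is called first, only, known or untested is meant among the compounds shown, and "the series" means these compounds.

Measured compounds:
compound 1, `COc1ccc(Cl)cc1S(=O)(=O)Nc1cncc(-c2cccnc2)c1`, 73 nM
compound 2, `COc1ccc(S(=O)(=O)Nc2cccnc2)c(OC)c1`, 10300 nM

Both compounds were tested in an assay on isolated protein for inhibition of alkaline phosphatase, tissue-nonspecific isozyme (Homo sapiens); a higher number here means a weaker inhibitor, a lower number a stronger inhibitor. Compound 1 gives 73 nM, the lowest of the two numbers, and compound 2 gives 10300 nM, a markedly higher number that lies well beyond the usual scatter of repeated measurements. The two compounds differ in several places at once, so the numbers alone do not say which part of compound 1 is responsible for its stronger inhibition.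

The step followed here leads from compound 1 to compound 3, `COc1ccc(Cl)cc1S(=O)(=O)Nc1cncc(-c2cccc(C)c2)c1`, which has not yet been measured in this assay. The change is a single one: 3-methylphenyl in place of pyridin-3-yl on an aromatic carbon. For the measured compounds named here, no step between two measured compounds that differ in only one place is available to guide the expectation, so the estimate rests on compound 1 alone. A small step is expected, if any, with the number of compound 3 perhaps slightly higher than that of compound 1, and a result inside the usual scatter would not be surprising. Compound 3 is therefore estimated at 110 nM, with a range from 30 nM to 400 nM, which means an expected step of a 1.5-fold higher number from compound 1 to compound 3 (0.18 log units; within the scatter).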

Compound 3, half-maximal inhibitory concentration: 160 nM
Compound 3: the middle estimate sits 1.5-fold (0.16 log units) below what was measured, and the stated range covers the measured number.
By their numbers in this assay, from the lowest: compound 1; then compound 3; then compound 2.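

In this assay, for the compounds shown here, this is the first comparison in which only one place changes, and putting 3-methylphenyl in place of pyridin-3-yl gives a 2.2-fold higher number from compound 1 to compound 3 (0.34 log units; beyond the scatter), a modest step that lies just beyond the usual scatter. The ring nitrogen of pyridin-3-yl is therefore not essential for inhibition at this position: compound 3, whose group has a ring of carbon only and no hydrogen-bond acceptor, still gives 160 nM, though it is a somewhat weaker inhibitor than compound 1. No measurement is available to explain this modest loss.

The swap removes a ring nitrogen and adds a methyl group at the same time, so these compounds cannot show which of the two changes accounts for the step, and an unsubstituted phenyl group at this position would begin to separate them. As far as these compounds go, it also remains open how the number would respond to other groups on this ring, such as an amine or a carboxylic acid, or to a methyl group placed elsewhere on it.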